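The compounds below may be only part of what the source reports. "The series", "measured", "known", "first", "only" and "open" are said of these compounds alone.

Measured so far in a functional assay on the whole organism (strain Wistar) for inhibition, with Rattus norvegicus as the target, read by paw edema, with a stated time of 2 h, at a dose of 100 mg/kg; a higher number here means more inhibition at the dose given (going by the name of the read-out), a lower number less inhibition:
compound 1 `COc1cc2c(cc1OC)C(CC(=O)Nc1ccccc1)CC2`: 32%
compound 2 `COc1cc2c(cc1OC)C(CC(=O)Nc1cccc(C)c1)CC2`: 29%
compound 3 `COc1cc2c(cc1OC)C(CC(=O)Nc1ccccn1)CC2`: 32%

Compound 3 sits level with compound 1 at the digits shown (no change at the digits printed from compound 1 to compound 3 (within the scatter)), and against compound 2 the step is a number 3 percentage points higher from compound 2 to compound 3 (within the scatter); all three numbers lie within the usual scatter of one another.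

Compound 4 `COc1cc2c(cc1OC)C(CC(=O)Nc1cccnc1)CC2` differs from compound 3 by pyridin-3-yl in place of pyridin-2-yl on an amide-type nitrogen. Among the measured compounds shown here, the measured steps that touch the same place are no change at the digits printed from compound 1 to compound 3 (within the scatter) and a number 3 percentage points higher from compound 2 to compound 3 (within the scatter), both within the scatter; no measured step moves the ring nitrogen of the pyridin-2-yl group itself. On this basis no step beyond the scatter is expected in this assay; the expected step is a number 1 percentage points lower from compound 3 to compound 4 (within the scatter). Compound 4 is estimated at 31%, with a range of 19% to 43%.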

Compound 4, a percentage reported as inhibition, in the whole organism at one dose (the size of the read-out at that dose, not a potency): 30%
Estimate against measurement, compound 4: 1 percentage points above, and the stated range covers the measured number.
By their numbers in this assay, from the lowest: compounds 2, 4, 1 and 3 (each within the scatter of the next).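

In this assay, among the compounds shown here, the change from pyridin-2-yl to pyridin-3-yl on the amide-type nitrogen is the first measured step that relocates the ring nitrogen, and it gives a number 2 percentage points lower from compound 3 to compound 4 (within the scatter) so the place of that nitrogen makes no readable difference here. Against 3-methylphenyl and phenyl on the same nitrogen the steps read a number 1 percentage points higher from compound 2 to compound 4 (within the scatter) and a number 2 percentage points lower from compound 1 to compound 4 (within the scatter) so the four groups remain indistinguishable at this dose. No available evidence accounts for this result. Open, as far as these compounds go, is whether an amine or a carboxylic acid on the pyridin-3-yl ring would give a step beyond the scatter. The shared core stays constant throughout, so its contribution remains unread.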